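Aryloxy variation on the ketone side of the series

The source may hold more compounds than are shown below. What is called first, only, known or untested is meant among the compounds shown, and "the series" means these compounds.

Compound 1 `CC(C)[C@H](NC(=O)COc1cccc2ccccc12)C(=O)N[C@@H](CC(=O)O)C(=O)COc1ccc2ccccc2c1` carries the naphthalen-2-yl group on the oxygen on a saturated carbon. Going by the values given here, in a functional assay with Homo sapiens as the target (a lower number here means a stronger inhibitor, a higher number a weaker inhibitor), compound 1 gives 15900 nM, the second highest of the three numbers so far. Compound 3 `CC(C)[C@H](NC(=O)COc1cccc2ccccc12)C(=O)N[C@@H](CC(=O)O)C(=O)COc1ccccc1F` gives 15700 nM in this assay, and compound 2 `CC(C)[C@H](NC(=O)COc1cccc2ccccc12)C(=O)N[C@@H](CC(=O)O)C(=O)COc1ccc(-c2ccccc2)cc1` gives 38700 nM.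

The step to compound 4 `CC(C)[C@H](NC(=O)COc1cccc2ccccc12)C(=O)N[C@@H](CC(=O)O)C(=O)COc1ccc(F)cc1` is 4-fluorophenyl in place of naphthalen-2-yl on an oxygen on a saturated carbon.

Among the compounds with values here, two measured steps bear on this. The change a 1.0-fold lower number from compound 1 to compound 3 (0.01 log units; within the scatter) shows that a small fluorinated phenyl at this position leaves the number where it was. The change a 2.4-fold higher number from compound 1 to compound 2 (0.39 log units; beyond the scatter) shows that a larger 4-phenylphenyl group raises the number modestly, and a 2.5-fold lower number from compound 2 to compound 3 (0.39 log units; beyond the scatter) points the same way. Compound 4 sits with compound 3 rather than compound 2 in the size of the entering group, so no step beyond the scatter is expected from compound 1 to compound 4; the expected step is a 1.0-fold higher number from compound 1 to compound 4 (0.00 log units; within the scatter).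

Compound 4 is therefore expected at 16000 nM, with a range from 6000 nM to 40000 nM.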

Compound 4, half-maximal inhibitory concentration: 14300 nM
Compound 4: the middle estimate sits 1.1-fold (0.05 log units) above what was measured, and the stated range covers the measured number.
By their numbers in this assay, from the lowest: compounds 4, 3 and 1 (each within the scatter of the next); then compound 2.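

In this assay, the change a 1.1-fold lower number from compound 1 to compound 4 (0.05 log units; within the scatter) shows that 4-fluorophenyl can stand in place of naphthalen-2-yl on this oxygen with no step beyond the scatter, and the change a 1.1-fold lower number from compound 3 to compound 4 (0.04 log units; within the scatter) shows that 4-fluorophenyl and 2-fluorophenyl cannot be told apart here. The change a 2.7-fold lower number from compound 2 to compound 4 (0.43 log units; beyond the scatter) gives a second fluorinated phenyl that stands apart from compound 2, so of the four compounds only the 4-phenylphenyl group departs from the others. No measured evidence accounts for these results.

As far as these compounds go, it remains open whether a pyridin-3-yl ring or a morpholine on this oxygen would shift the number beyond the scatter. From the compounds shown here alone, a methoxy or an amine on the phenyl ring in place of fluoro is equally open.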